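Dimethoxyphenyl on the carbonyl of a chalcone-type core

The source may hold more compounds than are shown below. What is called first, only, known or untested is meant among the compounds shown, and "the series" means these compounds.

Compound 1 `COc1cc(C(=O)/C=C/c2cc(-c3cc(OC)c(OC)c(OC)c3)n3nc(-c4ccccc4)cc3n2)cc(OC)c1OC`: 24300 nM
Compound 2 `COc1ccc(C(=O)/C=C/c2cc(-c3ccc(OC)c(OC)c3)n3nc(-c4ccccc4)cc3n2)cc1OC`: 2600 nM
Compound 3 `COc1cc(-c2cc(/C=C/C(=O)c3ccc(C)c(C)c3)nc3cc(-c4ccccc4)nn23)cc(OC)c1OC`: 13500 nM

In a functional assay on MDA-MB-231 cells (Homo sapiens) for antiproliferative activity, read by MTT assay, with a stated time of 24 h (on this read-out higher numbers stand for weaker inhibition and lower numbers for stronger inhibition), compound 3 gives the second highest of the three numbers. Its nearest neighbour is compound 1, reached by the one-place step a 1.8-fold lower number from compound 1 to compound 3 (0.26 log units; within the scatter); compound 2 lies further off, and since compound 2 differs from compound 3 in more than one place, only its value itself can be set against that of compound 3.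

Compound 4 `COc1ccc(C(=O)/C=C/c2cc(-c3cc(OC)c(OC)c(OC)c3)n3nc(-c4ccccc4)cc3n2)cc1OC` is not yet measured. It differs from compound 3 by 3,4-dimethoxyphenyl in place of 3,4-dimethylphenyl on a carbonyl carbon. For the measured compounds named here, the one step that bears on this place, from compound 1 to compound 3, was within the scatter, so exchanging the ring on the carbonyl carbon has so far moved the number little. Compound 2, which also carries a 3,4-dimethoxyphenyl on a carbonyl carbon, shows the lowest number of the three, but it differs elsewhere as well. Compound 4 is therefore expected to give 9000 nM, between 3000 nM and 27000 nM, an estimated step of a 1.5-fold lower number from compound 3 to compound 4 (0.18 log units; within the scatter).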

Compound 4, half-maximal inhibitory concentration: 18300 nM
Compound 4: middle estimate off by 2.0-fold (0.31 log units), on the low side; measured number inside the range.
By their numbers in this assay, from the lowest: compound 2; then compounds 3, 4 and 1 (each within the scatter of the next).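

With this assay as the read-out, the ring on the carbonyl carbon again counts for little: 3,4-dimethoxyphenyl in place of 3,4-dimethylphenyl gives a 1.4-fold higher number from compound 3 to compound 4 (0.13 log units; within the scatter), and hydrogen in place of methoxy on an aromatic carbon of that ring gives a 1.3-fold lower number from compound 1 to compound 4 (0.12 log units; within the scatter). For the compounds shown here, the only step beyond the scatter lies in the other ring: with the same 3,4-dimethoxyphenyl on the carbonyl carbon, methoxy in place of hydrogen on an aromatic carbon gives a 7.0-fold higher number from compound 2 to compound 4 (0.85 log units; beyond the scatter), so the low number of compound 2 goes with that other ring and not with the ring on the carbonyl carbon. Nothing available explains why this one methoxy matters.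

As far as these compounds go, compound 2 alone carries its ring pattern, so it stays open whether the ring on the carbonyl carbon would also count for little alongside it. From the compounds shown here alone, it is equally open whether an amine or a carboxylic acid on the ring on the carbonyl carbon would move the number.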